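Cytotoxicity of compound 4 expected to stay at the limit

The source may report more compounds than this note shows. Statements on the series, on what has been measured and on what is new or still open speak of the compounds shown alone.

The measured compounds:
- compound 1, `Cc1ccc2[nH]c(=O)c(CN(Cc3ccc(F)cc3)Cc3ccc(C(C)(C)C)cc3)cc2c1`: > 27000 nM
- compound 2, `CCc1ccc2[nH]c(=O)c(CN(Cc3ccc(F)cc3)Cc3ccc(C(C)(C)C)cc3)cc2c1`: > 33000 nM
- compound 3, `CCc1ccc2[nH]c(=O)c(CN(Cc3ccc(F)cc3)Cc3ccc4ccccc4c3)cc2c1`: > 5000 nM

In a toxicity assay on MDCK cells (Canis lupus familiaris) for cytotoxicity, read by crystal violet staining, with a stated time of 48 h (on this read-out lower numbers stand for higher toxicity in this test and higher numbers for lower toxicity in this test), compound 2 gives > 33000 nM, which is a limit of the assay rather than a number. Compound 1 likewise gives only a limit, > 27000 nM. Compound 3 also gives only a limit, > 5000 nM. So compound 2 stands among three values that are all limits, and none of the three can be ordered against another.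

Compound 4, `CCc1ccc2[nH]c(=O)c(CN(Cc3ccc(C(C)(C)C)cc3)[C@@H](C)c3ccc(OC)cc3)cc2c1`, differs from compound 2 in one place: 1-(4-methoxyphenyl)ethyl in place of 4-fluorobenzyl on an amine nitrogen. Among the measured compounds shown here, two measured steps bear on this by touching the same shared core and the same amine nitrogen. The step that the two limits leave unreadable from compound 1 to compound 2 is unreadable because of the limit of > 27000 nM in this assay, at which 1 of the 3 values shown sits, and (the limit of > 33000 nM in this assay, at which 1 of the 3 values shown sits). The step that the two limits leave unreadable from compound 2 to compound 3 is unreadable because of the limit of > 33000 nM in this assay, at which 1 of the 3 values shown sits, and (the limit of > 5000 nM in this assay, at which 1 of the 3 values shown sits). Neither step shows any toxicity appearing within the tested range, so no direction is known, and no step beyond the scatter is expected in this assay.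

Compound 4 is therefore expected to sit at 30000 nM, with a range from 10000 nM to 100000 nM. The step of an at least 1.1-fold lower number from compound 2 to compound 4 (0.04 log units; that floor lies within the scatter) is estimated to be within the scatter, and most likely the assay will again report only a limit.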

Compound 4, half-maximal cytotoxic concentration: > 5000 nM
Compound 4: no number, only a limit; the forecaster's own chance of this, stated with the estimate: 70%; the middle value does not contradict the limit.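

In this assay compound 4 gives > 5000 nM, which is a limit of the assay and not a number. Compound 2 also gives only a limit, so the step from compound 2 to compound 4 cannot be read. The compounds shown leave open whether, and at what concentration, any of them would prove toxic in this test.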